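The source may report more compounds than this note shows. Statements on the series, on what has been measured and on what is new or still open speak of the compounds shown alone.

Compound 1 `COC(=O)[C@@]1(C)CCC=C2[C@@H]1CC[C@@H](C)[C@]2(C)Cc1c(C)[nH]c2c(C)cccc12` gives 14000 nM in a functional assay on HeLa cells (Homo sapiens) for inhibition, read by sulforhodamine B assay, with a stated time of 48 h; a higher number here means a weaker inhibitor of growth, a lower number a stronger inhibitor of growth. Compound 2 `COC(=O)[C@@]1(C)CCC=C2[C@@H]1CC[C@@H](C)[C@]2(C)Cc1c(C)[nH]c2c(Br)cccc12` gives 22000 nM. Compound 3 `COC(=O)[C@@]1(C)CC[C@@H]2C3=C1CC[C@@H](C)[C@]3(C)Cc1c2[nH]c2ccc(C)cc12` gives 11000 nM.

Compound 2 differs from compound 1 by bromo in place of methyl on an aromatic carbon, a change that made a 1.6-fold higher number from compound 1 to compound 2 (0.20 log units; within the scatter). Compound 4 `COC(=O)[C@@]1(C)CC[C@@H]2C3=C1CC[C@@H](C)[C@]3(C)Cc1c2[nH]c2ccc(Br)cc12` has not been measured in this assay; it differs from compound 3 by bromo in place of methyl on an aromatic carbon. This is the same kind of change, though the surroundings differ: in compound 4 the aromatic carbon is part of a fused or bridged system of five rings, meta to a fused ring and para to a fused ring, whereas in compound 2 it is part of a fused or bridged system of two rings, ortho to a fused ring and meta to a fused ring. The difference between the cores of compound 1 and compound 3 is not broken down here. A step of about a 1.4-fold higher number from compound 3 to compound 4 (0.13 log units; within the scatter) is expected in this assay, resting on the earlier step of a 1.6-fold higher number from compound 1 to compound 2 (0.20 log units; within the scatter). Compound 4 is therefore expected to give 15000 nM, plausibly between 6000 nM and 40000 nM.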

Compound 4, concentration for 50% growth inhibition: 14000 nM
The estimate for compound 4 lay 1.1-fold (0.03 log units) above the measured number; low and high end bracket the measured number.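

In this assay, putting bromo in place of methyl on an aromatic carbon gave a 1.3-fold higher number from compound 3 to compound 4 (0.10 log units; within the scatter). Set beside the earlier step, the change behaved alike on both cores: the same change on two cores in this assay, a 1.6-fold higher number (0.20 log units; within the scatter) from compound 1 to compound 2 and a 1.3-fold higher number (0.10 log units; within the scatter) from compound 3 to compound 4, 1.2-fold (0.09 log units) apart, within the scatter of two such steps This shows only that the swap stayed within the scatter on these two cores, with the aromatic carbon placed differently in each; it does not show that the change has a real effect on growth inhibition, or that it would stay this small on any other core.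

The compounds shown leave open whether a different group on this aromatic carbon, such as an amine or a carboxylic acid, would move the number beyond the scatter. They also leave open what a carboxylic acid in place of the methyl ester would do.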